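The source may hold more compounds than are shown below. What is called first, only, known or untested is meant among the compounds shown, and "the series" means these compounds.

Working notes on the hexyl carbamoyl series. Three compounds have been examined so far in an assay on HEK293 cells for inhibition of acid ceramidase (Rattus norvegicus), read by LC-MS, with a stated time of 30 min; on this read-out lower numbers stand for stronger inhibition and higher numbers for weaker inhibition. Compound 1 `CCCCCCNC(=O)n1cc(C(F)(F)F)c(=O)[nH]c1=O` carries a trifluoromethyl on the shared core and gives 12 nM. Compound 2 `CCCCCCNC(=O)n1cc(C#N)c(=O)[nH]c1=O` carries a nitrile in the same place; in this assay compound 2 gives no result reported. Compound 3 `CCCCCCNC(=O)n1cc(F)c(=O)n(CC)c1=O` carries fluoro and an ethyl on an aromatic nitrogen, and in this assay compound 3 gives 18 nM. Among the measured compounds shown here, compound 3 thus holds the highest of the two numbers known, yet its nearest neighbour is compound 1 at a gap that stays within the scatter, so the two read as equivalent; compound 2 contributes no number.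

The next compound, compound 4 `CCCCCCNC(=O)n1cc(F)c(=O)n(C(=O)OCC)c1=O`, differs from compound 3 in one place: ethoxycarbonyl in place of ethyl on an aromatic nitrogen. For the measured compounds named here, no step between two measured compounds covers a change of this kind, so the expectation rests on compound 3 alone. The step is expected to be small, possibly toward a somewhat higher number, but not clearly beyond the scatter; the expected step is a 1.7-fold higher number from compound 3 to compound 4 (0.22 log units; within the scatter). For compound 4 the estimated value in this assay is 30 nM, with a range from 8 nM to 120 nM.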

Compound 4, half-maximal inhibitory concentration: 12 nM
Compound 4: the middle estimate sits 2.5-fold (0.40 log units) above what was measured, within the range that was stated.
By their numbers in this assay, from the lowest: compounds 1, 4 and 3 (each within the scatter of the next).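

At this position, the aromatic nitrogen two atoms from the ring nitrogen, the series now has its first measured step: ethoxycarbonyl in place of ethyl gives a 1.5-fold lower number from compound 3 to compound 4 (0.18 log units; within the scatter) in this assay and leaves compound 3 and compound 4 equivalent. The change from 2 to 5 heavy atoms, bringing in a double bond and 2 hydrogen-bond acceptors, therefore produces no step beyond the scatter in this pair. No supporting measurement is available to explain why the two compounds read alike.

On these data alone, it remains open whether this equivalence extends to other groups on the same nitrogen, such as a primary amine, a carboxylic acid, a benzyl group or a longer alkyl chain. As far as these compounds go, it is also open whether ethoxycarbonyl at this position gives the same reading with trifluoromethyl in place of fluoro on the shared core.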